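Swapping 1H-imidazol-1-yl for furan-3-yl at the assay limit

The source may report more compounds than this note shows. Statements on the series, on what has been measured and on what is new or still open speak of the compounds shown alone.

Values measured in a functional assay on PC-3 cells (Homo sapiens) for antiproliferative activity, read by CCK-8 assay, with a stated time of 6 days (a higher number here means a weaker inhibitor, a lower number a stronger inhibitor), are as follows.
Compound 1 `CCN(c1ccc(C#N)c(Cl)c1)c1cc(-c2ccccc2)ccc1C` reads "not determined" (no result reported) here
Compound 2 `CCN(c1ccc(C#N)c(Cl)c1)c1cc(-c2cccs2)ccc1C` reads > 30000 nM as a limit
Compound 3 `CCN(c1ccc(C#N)c(Cl)c1)c1cc(-n2ccnc2)ccc1C` reads > 30000 nM as a limit

Compound 3 stands at > 30000 nM in this assay and this is a limit, not a number. That mark is the limit of > 30000 nM in this assay, at which 2 of the 3 values shown sit, and the remaining entry gives no result, so the series offers no single number to start from.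

Compound 4 `CCN(c1ccc(C#N)c(Cl)c1)c1cc(-c2ccoc2)ccc1C` differs from compound 3 as follows: furan-3-yl in place of 1H-imidazol-1-yl on an aromatic carbon with furan-3-yl in place of 1H-imidazol-1-yl on an aromatic carbon, meta to a large group and para to a methyl group.

For the measured compounds named here, only one measured step bears on this change. It is a step that the two limits leave unreadable from compound 2 to compound 3 and it gives no readable size. The expectation therefore rests on compound 2, which stands at > 30000 nM as a limit. It rests equally on compound 3, which stands at > 30000 nM as a limit. Neither gives a reason to expect a gain beyond the scatter, and compound 4 is expected to stay near the limit, quite possibly reported only as one.

The expected step is a number no higher from compound 3 to compound 4 (the limit leaves the size open) in this assay and no clear direction is foreseen. The estimate for compound 4 is 30000 nM with 12000 nM to 60000 nM as the expected range.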

Compound 4, half-maximal inhibitory concentration: > 30000 nM
Compound 4 gave a limit, no number; the forecaster's own chance of this, stated with the estimate: 75%; the middle value sits exactly at the limit.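

In this assay compound 4 gives > 30000 nM, which is a limit and not a number. No step can be read among compound 2, compound 3 and compound 4, as all three stand only at the same mark: the limit of > 30000 nM in this assay, at which 3 of the 4 values shown sit.

The compounds shown leave open which group at this place, if any, would give a readable number in this assay.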